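Exchanging the aryl group on the triazole nitrogen

A few compounds are considered here, and "the series" means these few. Any claim that something is new, unique, unknown or untested is made for them only; others in the source may bear on it.

Compound 1, `Cc1ccccc1-n1nncc1CN1C(=O)C2(C(C#N)=C(N)Oc3c(N)cc4nc5ccccc5nc4c32)c2ccccc21` — in a functional assay on MCF7 cells (Homo sapiens) for antiproliferative activity, read by MTT assay, with a stated time of 48 h (a higher number here means a weaker inhibitor, a lower number a stronger inhibitor), compound 1 gives > 50000 nM, a limit of the assay.
Compound 2, `N#CC1=C(N)Oc2c(N)cc3nc4ccccc4nc3c2C12C(=O)N(Cc1cnnn1-c1ccc(Cl)cc1[N+](=O)[O-])c1ccccc12` — in this assay compound 2 gives > 50000 nM, also a limit.

Neither measured compound reached a number: both stand at the limit of > 50000 nM in this assay, at which 2 of the 2 values shown sit. Going by the values given here, the one step between them, a step that the two limits leave unreadable from compound 1 to compound 2, therefore has no readable size, and nothing can be said about which of the two is the stronger inhibitor. Compound 2 thus stands only at a limit in this assay.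

Compound 3, `Cc1cc(C)c(-n2nncc2CN2C(=O)C3(C(C#N)=C(N)Oc4c(N)cc5nc6ccccc6nc5c43)c3ccccc32)c(C)c1`, has not been measured. It differs from compound 2 by 2,4,6-trimethylphenyl in place of 4-chloro-2-nitrophenyl on an aromatic nitrogen. Among the compounds with values here, the only measured step also exchanged the group on that same aromatic nitrogen, and it gave nothing readable, so there is no measured basis for expecting a change in either direction beyond the scatter. Compound 3 is therefore expected to give 60000 nM in this assay, within 20000 nM to 200000 nM, most likely reported again as a limit. The expected step that the limit leaves unreadable from compound 2 to compound 3 is correspondingly an estimate with no measured support for a shift.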

Compound 3, half-maximal inhibitory concentration: > 50000 nM
Compound 3: a limit, no number; the forecaster's own chance of this, stated with the estimate: 85%; the middle value does not contradict the limit.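

In this assay compound 3 gives > 50000 nM, again a limit and not a number, so its steps from compound 1 and compound 2 cannot be read. The compounds shown leave open whether any group on that aromatic nitrogen would give a measurable value.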